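Moving a Fluorine on a Weak Cytotoxicity Probe

The source may report more compounds than this note shows. Statements on the series, on what has been measured and on what is new or still open speak of the compounds shown alone.

Going by the values given here, compound 2 `O=[N+]([O-])c1ccc(CN2CCC(n3cc(CC(OCc4cc(-c5cccc(F)c5)no4)c4ccc(Br)cc4)nn3)CC2)cc1` is the only compound of this set with a definite number in an ADME assay on cells (Fibroblast, Homo sapiens) for cytotoxicity, with a stated time of 48 h; a higher number here means a weaker inhibitor, a lower number a stronger inhibitor: compound 2 gives 10000 nM. Compound 1 `N#Cc1ccc(-c2cc(COC(Cc3cn(C4CCN(Cc5ccc([N+](=O)[O-])cc5)CC4)nn3)c3ccc(Br)cc3)on2)cc1` reaches only a limit in this assay, > 25000 nM. That limit is the limit of > 25000 nM in this assay, at which 1 of the 2 values shown sits. Among the compounds with values here, the one measured step, an at least 2.5-fold lower number from compound 1 to compound 2 (0.39 log units; beyond the scatter), therefore rests on that limit and gives only a lower bound for the change that a 3-fluorophenyl in place of a 4-cyanophenyl brings. Compound 3 `O=[N+]([O-])c1ccc(CN2CCC(n3cc(CC(OCc4cc(-c5ccccc5F)no4)c4ccc(Br)cc4)nn3)CC2)cc1` is not yet measured; it differs from compound 2 by 2-fluorophenyl in place of 3-fluorophenyl on an aromatic carbon. Within the data shown here, no measured step merely shifts a fluorine on the phenyl, so none bears directly on this change; the step from compound 1 to compound 2 swapped a different group. The chemist therefore expects for compound 3 a step of no change at the digits printed from compound 2 to compound 3 (within the scatter), none beyond the scatter. For compound 3 in this assay the estimate is 10000 nM, within a range from 4000 nM to 25000 nM.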

Compound 3, half-maximal inhibitory concentration: > 25000 nM
Compound 3: only a limit was reported (the forecaster's own chance of this, stated with the estimate: 30%); at least 2.5-fold (0.39 log units) between middle value and limit.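

Compound 3 in this assay gives only a limit, > 25000 nM. Moving the fluorine alone, with the same atoms on the same aromatic carbon, gives an at least 2.5-fold higher number from compound 2 to compound 3 (0.39 log units; beyond the scatter), so the place of the fluorine on the phenyl counts in this assay, which the earlier swap of 4-cyanophenyl, a change of group as well as of place, could not show on its own. The step between compound 1 and compound 3 cannot be read, and the step to compound 3 is only a lower bound, since these readings rest on the limit: the limit of > 25000 nM in this assay, at which 2 of the 3 values shown sit.

Going by these compounds, how far compound 3 actually lies from compound 2 remains open. Also open, on these data alone, is whether a 4-fluorophenyl, or a methoxy group or a chlorine in place of the fluorine, would keep the number of compound 2 or follow compound 3.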